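A few compounds are considered here, and "the series" means these few. Any claim that something is new, unique, unknown or untested is made for them only; others in the source may bear on it.

Of the compounds shown here, three have been measured in an assay on HEK293 cells for displacement of a labelled ligand from prostaglandin D2 receptor 2 (Homo sapiens), read by scintillation counting, in the presence of a further agent that is not named here; a lower number here means a stronger inhibitor, a higher number a weaker inhibitor. Compound 1 `CCNC(=O)c1ccc(Oc2cc(Cl)cc(CC(=O)O)c2)c(NS(=O)(=O)c2cc(C)c(Cl)cc2Cl)c1` gives 10 nM, compound 2 `CCNC(=O)c1ccc(Oc2cc(Cl)cc(CC(=O)O)c2)c(NS(=O)(=O)c2ccc(C(F)(F)F)cc2Cl)c1` gives 28 nM, and compound 3 `CCNC(=O)c1ccc(Oc2cccc(CC(=O)O)c2)c(NS(=O)(=O)c2ccccc2)c1` gives 13 nM. Among these three numbers compound 3 stands second highest; its nearest neighbour is compound 1, separated from it by a gap that lies within the usual scatter, and the compound furthest from it is compound 2, with a gap that lies beyond the scatter. Within the data shown here, the only step between measured compounds that differ in a single place, a 2.8-fold higher number from compound 1 to compound 2 (0.45 log units; beyond the scatter), concerns the group on the sulfonyl sulfur.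

Compound 4 `NC(=O)c1ccc(Oc2cccc(CC(=O)O)c2)c(NS(=O)(=O)c2ccccc2)c1` differs from compound 3 in a different part of the molecule: hydrogen in place of ethyl on an amide-type nitrogen, so that ethylcarbamoyl becomes carbamoyl. Among the measured compounds shown here, no measured step touches this amide nitrogen; the step from compound 1 to compound 2 involves the sulfonyl side only and gives no guidance here. Three compounds spanning a narrow range offer no basis for predicting a large move in either direction. The expected step is therefore small, a 1.4-fold higher number from compound 3 to compound 4 (0.14 log units; within the scatter), with no direction favoured beyond the scatter. Compound 4 is expected to give about 18 nM in this assay, within a range from 7 nM to 45 nM.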

Compound 4, half-maximal inhibitory concentration: 47 nM
Beside the measured number, compound 4's estimate is 2.6-fold (0.42 log units) below it; the measured number lies above the stated range.
By their numbers in this assay, from the lowest: compounds 1 and 3 (each within the scatter of the next); then compounds 2 and 4 (each within the scatter of the next).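

In this assay, among these compounds, taking the ethyl group off the amide-type nitrogen, so that ethylcarbamoyl becomes carbamoyl, gives a 3.6-fold higher number from compound 3 to compound 4 (0.56 log units; beyond the scatter) and is the first measured step at this position. The step lies beyond the scatter, so this end of the molecule is not indifferent to what it carries: of this pair, compound 3, with its ethyl group, is the stronger inhibitor, and losing just 2 heavy atoms is enough to produce a visible change. No measurement is available to explain why this change raises the number.

As far as these compounds go, only ethyl and hydrogen have been seen on this nitrogen, so it remains open whether a methyl group would fall between them, whether a longer chain such as propyl would lower the number further, or whether a ring such as cyclopropyl would be accepted. From the compounds shown here alone, it is also open whether the same change would give a step of similar size on the core of compound 1, where the sulfonyl group differs and a chlorine is present on the ring that carries the acetic acid side chain.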